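A few compounds are considered here, and "the series" means these few. Any claim that something is new, unique, unknown or untested is made for them only; others in the source may bear on it.

Working notes on the amide series. Compound 1 `CCCCC(=O)Nc1ccc(N2CCN(c3ccc(OC[C@@H]4CO[C@@](Cn5cncn5)(c5ccc(Cl)cc5Cl)O4)cc3)CC2)cc1` and compound 2 `O=C(CCCc1ccccc1)Nc1ccc(N2CCN(c3ccc(OC[C@@H]4CO[C@@](Cn5cncn5)(c5ccc(Cl)cc5Cl)O4)cc3)CC2)cc1` share the same core and differ only in the acyl chain. For the measured compounds named here, in a functional assay on A549 cells (Homo sapiens) for inhibition, read by MTT assay, with a stated time of 48 h (on this read-out lower numbers stand for stronger inhibition and higher numbers for weaker inhibition), compound 1 gives 5340 nM, and compound 2 gives 3780 nM; the two values sit within the scatter of each other, so neither can be set apart from the other on present numbers, and the step of a 1.4-fold lower number from compound 1 to compound 2 (0.15 log units; within the scatter) is the only measured change available. Compound 3 `Cc1ccc(C(=O)Nc2ccc(N3CCN(c4ccc(OC[C@@H]5CO[C@@](Cn6cncn6)(c6ccc(Cl)cc6Cl)O5)cc4)CC3)cc2)o1` is not yet measured; it differs from compound 2 by 5-methylfuran-2-yl in place of 3-phenylpropyl on a carbonyl carbon. Going by the values given here, the one measured step concerns a change on the same chain, but it does not swap the chain for an aromatic ring on the carbonyl carbon, so it bears on the new step only loosely; it showed no movement beyond the scatter. For compound 3 the expected step is a 1.1-fold higher number from compound 2 to compound 3 (0.02 log units; within the scatter), meaning no shift beyond the scatter, with low confidence. Compound 3 is therefore estimated at 4000 nM in this assay, within a range of 1500 nM to 11000 nM.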

Compound 3, half-maximal inhibitory concentration: 4750 nM
The estimate for compound 3 lay 1.2-fold (0.07 log units) below the measured number, and the stated range covers the measured number.
By their numbers in this assay, from the lowest: compounds 2, 3 and 1 (each within the scatter of the next).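

In this assay, putting an aromatic ring directly on the carbonyl carbon in place of a saturated chain gives a 1.3-fold higher number from compound 2 to compound 3 (0.10 log units; within the scatter) and a 1.1-fold lower number from compound 1 to compound 3 (0.05 log units; within the scatter). This position, on a carbonyl carbon whose other neighbours are amide-type nitrogen, therefore shows no separation among 3-phenylpropyl, butyl and 5-methylfuran-2-yl, even though the entering group brings a five-membered aromatic ring with 1 hetero atom and 1 hydrogen-bond acceptor in place of the six-membered aromatic ring of 3-phenylpropyl. Nothing available explains this lack of separation.

As far as these compounds go, whether an amine or a carboxylic acid on the acyl group would move the number beyond the scatter remains open. Also open, from the compounds shown here alone, are the effects of a plain furan-2-yl without the methyl and of a chain longer than 3-phenylpropyl.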